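Ethyl for Methyl Transferred to the Pyrazole Core

A few compounds are considered here, and "the series" means these few. Any claim that something is new, unique, unknown or untested is made for them only; others in the source may bear on it.

Compound 1, `Cn1ncnc1-c1ccccc1NCC1=NCCN1`, gives 2 nM in an in vitro functional assay on cells (Fibroblast) for agonist activity at Alpha-1A adrenergic receptor (Homo sapiens); on this read-out higher numbers stand for an effect only at larger amounts of compound and lower numbers for an effect already at smaller amounts.
Compound 2, `CCn1ncnc1-c1ccccc1NCC1=NCCN1`, gives 1.26 nM.
Compound 3, `Cn1ccc(-c2ccccc2NCC2=NCCN2)n1`, gives 3.16 nM.

Compound 4, `CCn1ccc(-c2ccccc2NCC2=NCCN2)n1`, awaits measurement in this assay. It differs from compound 3 by methyl in place of hydrogen on a saturated chain carbon bound to an aromatic nitrogen. The same change has already been measured once, from compound 1 to compound 2: methyl in place of hydrogen on a saturated chain carbon bound to an aromatic nitrogen, which gave a 1.6-fold lower number from compound 1 to compound 2 (0.20 log units; within the scatter). The two cores on which this change is made differ by 1-methyl-1H-pyrazol-3-yl in place of 1-methyl-1H-1,2,4-triazol-5-yl on an aromatic carbon, and that exchange gave a 1.6-fold higher number from compound 1 to compound 3 (0.20 log units; within the scatter). Within the data shown here, all three measured numbers lie close together, and the one measured step for this change stayed within the scatter. A step of like size is therefore expected, a 1.6-fold lower number from compound 3 to compound 4 (0.20 log units; within the scatter), because the same change gave a 1.6-fold lower number from compound 1 to compound 2 (0.20 log units; within the scatter). Compound 4 is thus estimated at 2 nM, with a likely range from 1 nM to 4.5 nM.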

Compound 4, half-maximal effective concentration: 25.1 nM
Estimate against measurement, compound 4: 13-fold (1.10 log units) below, outside the stated range (above it).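

On the core of compound 3, methyl to ethyl gave a 7.9-fold higher number from compound 3 to compound 4 (0.90 log units; beyond the scatter) in this assay. The step seen on the core of compound 1 therefore did not carry over to this second core: the same change on two cores in this assay, a 1.6-fold lower number (0.20 log units; within the scatter) from compound 1 to compound 2 and a 7.9-fold higher number (0.90 log units; beyond the scatter) from compound 3 to compound 4, 13-fold (1.10 log units) apart, beyond the scatter of two such steps

Among these compounds, this shows that, for these two pairs, the outcome of the change depends on the core that carries it, but with only one pair on each core it does not show why, nor how the change would behave on any further core.

The compounds shown leave open whether a longer chain, such as propyl, in place of the ethyl would widen or narrow this gap between the two cores.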